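Chloromethyl for vinyl across two cores

The compounds below may be only part of what the source reports. "The series", "measured", "known", "first", "only" and "open" are said of these compounds alone.

Three compounds are measured in a functional assay on JeKo-1 cells (Homo sapiens) for inhibition, read by luminescence and CellTiter-Glo, with a stated time of 72 h; a higher number here means a weaker inhibitor, a lower number a stronger inhibitor. Compound 3 `C=CC(=O)Nc1ccc(Cn2nc(-c3ccc(Oc4ccccc4)cc3)cc2CO)cc1` gives 8000 nM, and compound 1 `O=C(CCl)Nc1ccc(Cn2nc(-c3ccc(Oc4ccccc4)cc3)cc2CO)cc1` gives 400 nM; the change between them is chloromethyl in place of vinyl on a carbonyl carbon and the step is a 20-fold lower number from compound 3 to compound 1 (1.30 log units; beyond the scatter). Compound 2 `C=CC(=O)N1CCCC(n2nc(-c3ccc(Oc4ccccc4)cc3)cc2C(=O)OCC)C1` gives 21200 nM, the highest number of the three; how its core differs from the core of compound 3 is not broken down here. Compound 4 `CCOC(=O)c1cc(-c2ccc(Oc3ccccc3)cc2)nn1C1CCCN(C(=O)CCl)C1` is not yet measured. It differs from compound 2 by chloromethyl in place of vinyl on a carbonyl carbon, the same kind of change as from compound 3 to compound 1, though here the carbonyl carbon's other neighbour is an amide-type nitrogen in a ring rather than an amide-type nitrogen. Because a 20-fold lower number from compound 3 to compound 1 (1.30 log units; beyond the scatter) was seen for this kind of change, a step in the same direction but somewhat smaller is expected, a 12-fold lower number from compound 2 to compound 4 (1.07 log units; beyond the scatter). Compound 4 is estimated at 1800 nM, between 500 nM and 8000 nM.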

Compound 4, half-maximal inhibitory concentration: 800 nM
For compound 4 the middle estimate is 2.3-fold (0.35 log units) above the measured one; measured number inside the range.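

In this assay, chloromethyl in place of vinyl on a carbonyl carbon whose other neighbour is an amide-type nitrogen in a ring gives a 27-fold lower number from compound 2 to compound 4 (1.42 log units; beyond the scatter). The change carries from the core of compound 3 to the core of compound 2 with its size preserved: the same change on two cores in this assay, a 20-fold lower number (1.30 log units; beyond the scatter) from compound 3 to compound 1 and a 27-fold lower number (1.42 log units; beyond the scatter) from compound 2 to compound 4, 1.3-fold (0.12 log units) apart, within the scatter of two such steps. This rests on two pairs in one read-out, so it does not show why the number drops or that the step would hold on any further core.

Open, as far as these compounds go, is whether bromomethyl or a longer chain such as chloroethyl on the same carbonyl carbon would follow chloromethyl. Also open, from the compounds shown here alone, is whether the step survives with a carboxylic acid or an amine in place of the ethyl ester of compound 4.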